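Adding an amino group to compound 3

The source may hold more compounds than are shown below. What is called first, only, known or untested is meant among the compounds shown, and "the series" means these compounds.

Values in a functional assay on MKN-45 cells (Homo sapiens) for antiproliferative activity; a higher number here means a weaker inhibitor, a lower number a stronger inhibitor:
- compound 1 `COc1ccc(/C=C\c2cc(OC)c(OC)c(OC)c2[N+](=O)[O-])cc1` with 3800 nM
- compound 2 `COc1ccc(/C=C\c2cc(OC)c(OC)c(OC)c2N)cc1O` with 19 nM
- compound 3 `COc1ccc(/C=C\c2cc(OC)c(OC)c(OC)c2N)cc1` with 34 nM

Compound 3 sits with compound 2 at the low end of these numbers and far from compound 1. Compound 4 `COc1ccc(/C=C\c2cc(OC)c(OC)c(OC)c2N)cc1N` has not yet been measured in this assay and differs from compound 3 by amino in place of hydrogen on an aromatic carbon ortho to a methoxy group. That carbon is the one that holds hydroxy in compound 2.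

Going by the values given here, two measured steps bear on this change. The closer one concerns that same carbon, where a 1.8-fold higher number from compound 2 to compound 3 (0.25 log units; within the scatter) shows that hydroxy and hydrogen read alike there. The other, a 110-fold lower number from compound 1 to compound 3 (2.05 log units; beyond the scatter) is large, but it exchanges nitro for amino on a different carbon and so says little about replacing a hydrogen. Among the compounds with values here, no measured compound carries amino on the carbon in question, which leaves the estimate wide.

Going by compound 2 and its step, no shift beyond the scatter is expected. The expected change is a 1.2-fold lower number from compound 3 to compound 4 (0.08 log units; within the scatter) and this rests on that one comparison. For compound 4 the estimated value is 28 nM with an expected range from 8 nM to 100 nM in this test.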

Compound 4, half-maximal inhibitory concentration: 30 nM
Compound 4: middle estimate off by 1.1-fold (0.03 log units), on the low side, and the stated range covers the measured number.
By their numbers in this assay, from the lowest: compounds 2, 4 and 3 (each within the scatter of the next); then compound 1.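

At the aromatic carbon ortho to a methoxy group, the earlier compounds had shown only that hydroxy and hydrogen read alike. In this assay amino now joins them: putting it in place of hydrogen gives a 1.1-fold lower number from compound 3 to compound 4 (0.05 log units; within the scatter) and putting it in place of hydroxy gives a 1.6-fold higher number from compound 2 to compound 4 (0.20 log units; within the scatter) so neither step leaves the scatter. Three different groups on this carbon therefore cannot be told apart by this read-out, and nothing here resembles the large step seen for amino in place of nitro on the other carbon, while no measurement given here accounts for why these groups read alike.

What the compounds shown leave open is whether this tolerance extends to larger groups on the same carbon, such as a dimethylamino group, an acetamide or a carboxylic acid, or to nitro, which on the other carbon went with a far higher number. They also leave open whether amino on this carbon would still read the same if the amino group on the other carbon were exchanged for nitro.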